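The compounds below may be only part of what the source reports. "The series", "measured", "known", "first", "only" and "open" are said of these compounds alone.

The measured compounds in a functional assay on JAR cells (Homo sapiens) for inhibition, read by MTT assay, with a stated time of 72 h, tested at 10 uM (on this read-out higher numbers stand for more inhibition at the one concentration tested (going by the name of the read-out) and lower numbers for less inhibition), are:

compound 1, `CCOC(=O)C1=C(Nc2ccccc2)S/C(=C\c2ccccc2)C1=O`: 20.3%
compound 2, `CCOC(=O)C1=C(Nc2ccccc2)S/C(=C\c2cc(OC)c(O)c(OC)c2)C1=O`: 57.5%
compound 3, `CCOC(=O)C1=C(Nc2ccc(Br)cc2)S/C(=C\c2ccc[nH]2)C1=O`: 41.5%

Among these three numbers compound 3 stands second highest. Its nearest neighbour is compound 2, whose number is higher by a difference that lies beyond the usual scatter; its furthest is compound 1, whose number is lower by a difference that likewise lies beyond the scatter. The three compounds differ from one another in more than one place, so no single change among them can be tied to a step in this assay.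

Compound 4, `CCOC(=O)C1=C(Nc2ccc(C)cc2)S/C(=C\c2ccc[nH]2)C1=O`, has not yet been measured. It differs from compound 3 in one place: methyl in place of bromo on an aromatic carbon. For the measured compounds named here, no measured pair shows a bromo-to-methyl exchange on an aromatic carbon of a six-membered aromatic ring of carbon only, so the size of this step rests on expectation alone. Since the exchanged groups are each a single heavy atom without donors or acceptors, the step is expected to be small, in no particular direction, and most likely within the scatter. The expected step is a number 1.5 percentage points lower from compound 3 to compound 4 (within the scatter). Compound 4 is accordingly estimated to give 40% in this assay. The estimate for compound 4 spans from 25% to 55%.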

Compound 4, a percentage reported as inhibition, at one concentration (the size of the read-out at that concentration, not a potency): < 10%
Compound 4 was reported as a limit; the forecaster's own chance of this, stated with the estimate: 0%; middle value at least 30 percentage points away from the limit.
By their numbers in this assay, from the lowest: compound 1; then compound 3; then compound 2. At a limit, below all of these: compound 4.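

In this assay, for the compounds shown here, the pair compound 3 and compound 4 gives the first step that can be read at a single place, and that place proves far from indifferent: methyl in place of bromo on an aromatic carbon, para to a large group, comes with a number at least 31.5 percentage points lower from compound 3 to compound 4 (beyond the scatter). The leaving and entering groups each count one heavy atom, no ring and no hydrogen-bond donors or acceptors, so these counts alone do not separate bromo from methyl here, while the read-out does. Compound 4 stands as a limit and not as a number, so the step gives only a lower bound on its size: the limit of < 10% in this assay, at which 1 of the 4 values shown sits.

The compounds shown leave open whether the step follows the loss of bromo or the arrival of methyl, since no other group at this place, such as chloro, methoxy or an amine, stands beside these two. They also leave open whether the same exchange would give a like step on the core of compound 2, which carries a different aromatic group at the other end of the molecule.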